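Cyano in Place of Methoxy on the Sulfonamide Phenyl

A few compounds are considered here, and "the series" means these few. Any claim that something is new, unique, unknown or untested is made for them only; others in the source may bear on it.

Of the compounds shown here, two have been measured in a functional assay on the whole organism (aorta) with Rattus norvegicus as the target; on this read-out lower numbers stand for smaller maximal responses and higher numbers for larger maximal responses. Compound 1 `CC1(C)C=C(n2ccccc2=O)c2cc(S(=O)(=O)NCCO)ccc2O1` gives 95.5%. For the measured compounds named here, compound 2 `COc1ccc(NS(=O)(=O)c2ccc3c(c2)C(n2ccccc2=O)=CC(C)(C)O3)cc1` gives 77.9%, the lowest of the two numbers, and the single measured step, a number 17.6 percentage points lower from compound 1 to compound 2 (beyond the scatter), separates them. Compound 3 `CC1(C)C=C(n2ccccc2=O)c2cc(S(=O)(=O)Nc3ccc(C#N)cc3)ccc2O1` has not yet been measured; it differs from compound 2 by cyano in place of methoxy on an aromatic carbon. Going by the values given here, no measured step concerns such an exchange on the 4-methoxyphenyl group: the one step known replaced the whole 2-hydroxyethyl group on the sulfonamide nitrogen and so bears on the present change only indirectly, showing that compound 2 already sits below compound 1. For compound 3 a step of about a number 0.1 percentage points higher from compound 2 to compound 3 (within the scatter) is expected, with no direction that would stand beyond the scatter. Compound 3 is therefore estimated to reach 78%, within a range from 58% to 96%.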

Compound 3, largest response reached (Emax), in percent of the reference or control that the assay uses: 84%
Compound 3: the middle estimate sits 6 percentage points below what was measured; low and high end bracket the measured number.
By their numbers in this assay, from the lowest: compounds 2 and 3 (each within the scatter of the next); then compound 1.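

In this assay, cyano in place of methoxy on the aromatic carbon para to a large group gives a number 6.1 percentage points higher from compound 2 to compound 3 (within the scatter), so the two groups cannot be told apart at this place on this read-out. The 4-cyanophenyl group on the sulfonamide nitrogen also leaves a number 11.5 percentage points lower from compound 1 to compound 3 (beyond the scatter), which shows that the gap to the 2-hydroxyethyl compound seen with 4-methoxyphenyl holds for a second substituent on the phenyl ring. No measurement at hand accounts for either step. The compounds shown leave open whether an amine or a carboxylic acid on the same aromatic carbon would stay within the scatter of compound 2 and compound 3. They also leave open whether a longer chain on the sulfonamide nitrogen would stand with compound 1 or with the phenyl compounds.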